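Piperidinol benzyl series: benzyl ring substitution, single measured point

The source may hold more compounds than are shown below. What is called first, only, known or untested is meant among the compounds shown, and "the series" means these compounds.

Measured compounds:
Compound 1 `O=c1c2cnn(-c3ccc(F)cc3)c2ncn1CC1(O)CCN(Cc2ccccc2)CC1`, in an assay on Sf21 cells for inhibition of ubiquitin carboxyl-terminal hydrolase 7 (Homo sapiens), read by spectrophotometry, with stated times of 30 min and 2 h (on this read-out lower numbers stand for stronger inhibition and higher numbers for weaker inhibition), compound 1 gives "not determined" (no result reported).
Compound 2 `O=c1c2cnn(-c3ccc(F)cc3)c2ncn1CC1(O)CCN(Cc2ccc(Br)cc2)CC1`, in this assay compound 2 gives 6700 nM.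
Compound 3 `Cc1ccc(CN2CCC(O)(Cn3cnc4c(cnn4-c4ccc(F)cc4)c3=O)CC2)cc1`, in this assay compound 3 gives "not determined" (no result reported).

Going by the values given here, compound 3 stands without a number in this assay; only compound 2 carries a value, and no step between measured compounds is available. Compound 4 `O=c1c2cnn(-c3ccc(F)cc3)c2ncn1CC1(O)CCN(Cc2ccc(F)cc2Cl)CC1` differs from compound 3 by 2-chloro-4-fluorophenyl in place of 4-methylphenyl on a saturated chain carbon bound to an amine nitrogen in a ring. Among the compounds with values here, with no measured step to rest on, the expected step in this assay is none beyond the scatter, in either direction, and the one number for compound 2 serves as the only anchor. For compound 4 the half-maximal inhibitory concentration in this assay is estimated at 5000 nM, with a range from 1000 nM to 25000 nM.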

Compound 4, half-maximal inhibitory concentration: 1600 nM
Compound 4: middle estimate off by 3.1-fold (0.49 log units), on the high side; the range from low to high includes it.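

In this assay, going by these compounds alone, the step of a 4.2-fold lower number from compound 2 to compound 4 (0.62 log units; beyond the scatter) is the first measured comparison at this position. It shows that the number here can move beyond the scatter when the ring substituents change. Nothing available bears on the origin of this step.

Whether the chlorine or the fluorine accounts for the step stays open. So does how a benzyl ring carrying a carboxylic acid or an amine would read.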